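Swapping a small nitrile arm for a chlorinated benzyl group

The source may hold more compounds than are shown below. What is called first, only, known or untested is meant among the compounds shown, and "the series" means these compounds.

Measured so far in an ADME assay on MT4 cells (Homo sapiens) for cytotoxicity, read by MTT assay, with a stated time of 5 days; on this read-out lower numbers stand for higher toxicity in this test and higher numbers for lower toxicity in this test:
- compound 1 `Cc1cc(C)c(Oc2cc(Nc3ccc(C#N)cc3)ncc2C(=O)NCc2cn(Cc3ccccc3F)nn2)c(C)c1`: a limit of the test, > 222000 nM
- compound 2 `Cc1cc(C)c(Oc2cc(Nc3ccc(C#N)cc3)ncc2C(=O)NCc2cn(CC(N)=O)nn2)c(C)c1`: 24000 nM
- compound 3 `Cc1cc(C)c(Oc2cc(Nc3ccc(C#N)cc3)ncc2C(=O)NCc2cn(CCC#N)nn2)c(C)c1`: 40200 nM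

All three share one core and differ only in the group carried on a saturated chain carbon bound to an aromatic nitrogen. Compound 3 gives the higher of the two plain numbers, though the step of a 1.7-fold higher number from compound 2 to compound 3 (0.22 log units; within the scatter) is within the scatter. The value of compound 1 is only a limit of this assay (the limit of > 222000 nM in this assay, at which 1 of the 3 values shown sits).

Compound 4 `Cc1cc(C)c(Oc2cc(Nc3ccc(C#N)cc3)ncc2C(=O)NCc2cn(Cc3ccc(Cl)cc3)nn2)c(C)c1` is not yet measured. It differs from compound 3 in this way: 4-chlorophenyl in place of cyanomethyl on a saturated chain carbon bound to an aromatic nitrogen. Of the measured steps, the nearest is an at least 5.5-fold lower number from compound 1 to compound 3 (0.74 log units; beyond the scatter), which runs the opposite way: an aryl group on that carbon gave a much higher number than cyanomethyl. The step of an at least 9.2-fold lower number from compound 1 to compound 2 (0.96 log units; beyond the scatter) points the same way.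

Compound 4 is therefore expected to show a clearly higher number in this assay than compound 3, a step of about a 3.7-fold higher number from compound 3 to compound 4 (0.57 log units; beyond the scatter). The estimate for compound 4 is 150000 nM, expected to fall between 45000 nM and 300000 nM, with a fair chance that only a limit is reported.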

Compound 4, half-maximal cytotoxic concentration: >= 120000 nM
Compound 4: only a limit was reported; the forecaster's own chance of this, stated with the estimate: 45%; the middle value does not contradict the limit.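

In this assay, replacing cyanomethyl or carbamoyl with 4-chlorophenyl on a saturated chain carbon bound to an aromatic nitrogen raises the number, giving an at least 2.9-fold higher number from compound 3 to compound 4 (0.47 log units; beyond the scatter) and an at least 5.0-fold higher number from compound 2 to compound 4 (0.69 log units; beyond the scatter). Before this, compound 1 was the only compound with an aromatic ring on this carbon, so the high number could have been peculiar to 2-fluorophenyl, whereas compound 4 shows that a ring with a different halogen in a different place also gives a high reading. Compound 1 and compound 4 each report only a limit, so the step between them cannot be read: the limit of >= 120000 nM in this assay, at which 1 of the 4 values shown sits.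

As far as these compounds go, it remains open whether the halogen matters at all, since an unsubstituted phenyl group on this carbon would test that. A cyclohexyl group, an amine or a longer carbon chain here could show whether the aromatic ring itself is needed for the high number.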